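A few compounds are considered here, and "the series" means these few. Any claim that something is new, unique, unknown or untested is made for them only; others in the source may bear on it.

- Compound 1 `Cc1ccccc1Nc1nc(Nc2ccc(N3CCN(C)CC3)cn2)ncc1Cl`: 8080 nM
- Compound 2 `CCN1CCN(c2ccc(Nc3ncc(Cl)c(Nc4ccccc4C)n3)nc2)CC1`: > 100000 nM
- Compound 3 `Cc1ccccc1Nc1nc(Nc2ccc(N3CCCCC3)cn2)ncc1Cl`: > 100000 nM

Among the compounds with values here, in a functional assay on Jurkat cells (Homo sapiens) for inhibition, read by CCK-8 assay, with a stated time of 48 h (on this read-out lower numbers stand for stronger inhibition of growth and higher numbers for weaker inhibition of growth), compound 1 gives 8080 nM, the only true number of the three. Compound 2 stands at > 100000 nM, which is a limit of the assay. Compound 3 stands at > 100000 nM, also a limit.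

Compound 4 `Cc1ccc(CNc2nc(Nc3ccc(N4CCN(C)CC4)cn3)ncc2Cl)cc1` differs from compound 1 at one place, with 4-methylbenzyl in place of 2-methylphenyl on a nitrogen on an aromatic ring. The two readable steps, an at least 12-fold higher number from compound 1 to compound 2 (1.09 log units; beyond the scatter) and an at least 12-fold higher number from compound 1 to compound 3 (1.09 log units; beyond the scatter), are large and beyond the scatter, but they changed a different group. They therefore bear on this change only loosely, and they raise the expectation of weaker inhibition in this assay, not stronger. The expected step is a 2.5-fold higher number from compound 1 to compound 4 (0.39 log units; beyond the scatter). For compound 4 the estimated value is 20000 nM, with an expected range of 4000 nM to 100000 nM.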

Compound 4, concentration for 50% growth inhibition: 12700 nM
Estimate against measurement, compound 4: 1.6-fold (0.20 log units) above, within the range that was stated.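

In this assay, swapping 2-methylphenyl for 4-methylbenzyl on this nitrogen gives a 1.6-fold higher number from compound 1 to compound 4 (0.20 log units; within the scatter), so compound 1 and compound 4 cannot be told apart. Within the data shown here, the earlier compounds varied only the 4-methylpiperazin-1-yl group, so this is the first view of this place, and this swap between two groups that each hold one six-membered aromatic ring of carbon only leaves the read-out unmoved.

As far as these compounds go, whether this place also accepts a carboxylic acid or a longer alkyl chain stays open. The step from compound 2 to compound 3 cannot be read because both sit at a limit: the limit of > 100000 nM in this assay, at which 2 of the 4 values shown sit.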